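This account rests on a few compounds, and the source may have more. Where it says the series, first, only, none or still open, it means among the compounds named here.

Among the compounds with values here, compound 2 `COc1ccc2c(c1)/C(=N/N1CC(=O)N(CCCCN3CCCCC3)C1=O)CCO2` gives the highest number of the two measured so far: in an assay on cells (Ventricular myocyte) for inhibition of potassium voltage-gated channel subfamily KQT member 1 (Cavia porcellus), read by patch clamp (on this read-out lower numbers stand for stronger inhibition and higher numbers for weaker inhibition), compound 2 gives 22000 nM, whereas compound 1 `COc1ccc2c(c1)/C(=N/N1CC(=O)N(CCCCN3CCN(C)CC3)C1=O)CCO2` gives 650 nM. Within the data shown here, the only measured step, a 34-fold higher number from compound 1 to compound 2 (1.53 log units; beyond the scatter), bears directly on the change to compound 3 `COc1ccc2c(c1)/C(=N/N1CC(=O)N(CCCN3CCN(C)CC3)C1=O)CCO2`, which reverses that swap while also shortening the chain: 4-methylpiperazin-1-yl in place of (piperidin-1-yl)methyl on a saturated chain carbon, three bonds along the chain from an amide-type nitrogen in a ring. Since the reverse of that step was so large, the number is expected to fall back toward that of compound 1, with the step of a 20-fold lower number from compound 2 to compound 3 (1.30 log units; beyond the scatter) expected. Compound 3 is therefore estimated at 1100 nM, within a range from 300 nM to 5000 nM.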

Compound 3, half-maximal inhibitory concentration: 1.9 nM
The estimate for compound 3 lay 580-fold (2.76 log units) above the measured number; measured number below the stated range.
By their numbers in this assay, from the lowest: compound 3; then compound 1; then compound 2.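

Within the data shown here, with the 4-methylpiperazin-1-yl group kept, shortening the chain alone moves the number far (a 340-fold lower number from compound 1 to compound 3 (2.53 log units; beyond the scatter)), so chain length at this position counts for much in this assay, which the earlier compounds could not show. The change from 4-(piperidin-1-yl)butyl to 3-(4-methylpiperazin-1-yl)propyl gives a step (a 12000-fold lower number from compound 2 to compound 3 (4.06 log units; beyond the scatter)) that exceeds either single change seen alone. Nothing measured here accounts for the size of these steps. From the compounds shown here alone, whether piperidin-1-yl on the shorter chain would match 4-methylpiperazin-1-yl remains open. So does the effect of a morpholin-4-yl group on that chain, or of a still shorter ethyl chain.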